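The source may report more compounds than this note shows. Statements on the series, on what has been measured and on what is new or still open speak of the compounds shown alone.

Series notes. Compound 1 `O=C1/C(=C/c2ccc(F)cc2)CCC/C1=C\c1cccc([N+](=O)[O-])c1` and compound 2 `O=C1/C(=C/c2ccc(Cl)cc2)CCC/C1=C\c1cccc([N+](=O)[O-])c1` share one core; compound 3 `O=C1/C(=C/c2ccc(F)cc2)CCC/C1=C\c1ccc([N+](=O)[O-])cc1` and the as yet unmeasured compound 4 `O=C1/C(=C/c2ccc(Cl)cc2)CCC/C1=C\c1ccc([N+](=O)[O-])cc1` share another. The difference between the two cores is not broken down here.

In a functional assay on HSC-4 cells (Homo sapiens) for cytotoxicity, with a stated time of 24 h (a lower number here means that less compound is tolerated, a higher number that more compound is tolerated), compound 1 gives 2500 nM, and compound 2 gives 2300 nM. The change between them is chloro in place of fluoro on an aromatic carbon, and it made a step of a 1.1-fold lower number from compound 1 to compound 2 (0.04 log units; within the scatter). For the measured compounds named here, compound 3 gives 15000 nM in this assay, the highest of the three numbers measured so far, beyond the scatter from both compound 1 and compound 2.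

Compound 4 differs from compound 3 by chloro in place of fluoro on an aromatic carbon, the same kind of change as from compound 1 to compound 2, at a place described in the same words. Given that the only observed instance of this change gave a 1.1-fold lower number from compound 1 to compound 2 (0.04 log units; within the scatter), which lies within the scatter, the expected step for compound 4 is a 1.1-fold lower number from compound 3 to compound 4 (0.03 log units; within the scatter). For compound 4 the estimate in this assay is 14000 nM, expected to lie between 6000 nM and 35000 nM, resting on that single observed step alone.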

Compound 4, half-maximal cytotoxic concentration: 2700 nM
Beside the measured number, compound 4's estimate is 5.2-fold (0.71 log units) above it; the measured number lies below the stated range.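

In this assay, chloro in place of fluoro on an aromatic carbon did not carry over unchanged from one core to the other: the same change on two cores in this assay, a 1.1-fold lower number (0.04 log units; within the scatter) from compound 1 to compound 2 and a 5.6-fold lower number (0.74 log units; beyond the scatter) from compound 3 to compound 4, 5.1-fold (0.71 log units) apart, beyond the scatter of two such steps

The new step, a 5.6-fold lower number from compound 3 to compound 4 (0.74 log units; beyond the scatter), is therefore no copy of the earlier step, a 1.1-fold lower number from compound 1 to compound 2 (0.04 log units; within the scatter), and in these two pairs the size of the step depends on the core, so a step read on one core gives a poor estimate for the other. This does not show which feature of the cores sets the difference or whether it would hold for other changes, and each core offers a single pair, so the result rests on two steps only.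

As far as these compounds go, it remains open how bromo, methyl or methoxy in place of the chloro would behave on each core, and whether the gap between the steps would persist with an amine in place of the nitro group. Also open, from the compounds shown here alone, is whether the same gap would appear in a read-out other than this assay.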